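Adding a Second Chloro Group: Expected Effect on Growth Inhibition

A few compounds are considered here, and "the series" means these few. Any claim that something is new, unique, unknown or untested is made for them only; others in the source may bear on it.

Of the compounds shown here, three sharing a common core have been tested in a functional assay on HeLa cells (Homo sapiens) for antiproliferative activity, read by MTT assay, with a stated time of 48 h, in the presence of a further agent that is not named here; on this read-out higher numbers stand for weaker inhibition of growth and lower numbers for stronger inhibition of growth. Compound 1 `Cc1ccc(-c2nn(-c3ccccc3)cc2C(=O)NOCc2ccccc2Cl)cc1` gives 4680 nM. Compound 2 `Cc1ccc(-c2nn(-c3ccccc3)cc2C(=O)NOCc2ccc(Cl)cc2Cl)cc1` differs from compound 1 by chloro in place of hydrogen on an aromatic carbon, and in this assay compound 2 gives 2040 nM; the change produced a 2.3-fold lower number from compound 1 to compound 2 (0.36 log units; beyond the scatter). Compound 3 `O=C(NOCc1ccccc1Cl)c1cn(-c2ccccc2)nc1-c1ccc(Cl)cc1` differs from compound 1 in the core by chloro in place of methyl on an aromatic carbon, and in this assay compound 3 gives 8850 nM; that is a 1.9-fold higher number from compound 1 to compound 3 (0.28 log units; within the scatter). Compound 3 thus carries the highest number of the three, although its gap to compound 1 lies within the usual scatter, while its gap to compound 2 lies beyond it.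

Compound 4 `O=C(NOCc1ccc(Cl)cc1Cl)c1cn(-c2ccccc2)nc1-c1ccc(Cl)cc1` has not yet been measured. It differs from compound 3 by chloro in place of hydrogen on an aromatic carbon. Going by the values given here, this is the same change as the one from compound 1 to compound 2, made here on the core of compound 3 rather than the core of compound 1. Among the compounds with values here, that earlier example produced a 2.3-fold lower number from compound 1 to compound 2 (0.36 log units; beyond the scatter), and it is the only example of this change among the measured compounds. On that basis the expected step is a 2.3-fold lower number from compound 3 to compound 4 (0.36 log units; beyond the scatter). Compound 4 is therefore estimated at 3900 nM, with a likely range from 1800 nM to 9000 nM; the range is kept wide since the expectation rests on a single earlier instance of the change.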

Compound 4, concentration for 50% growth inhibition: 5160 nM
Estimate against measurement, compound 4: 1.3-fold (0.12 log units) below; low and high end bracket the measured number.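

Going from 2-chlorobenzyl to 2,4-dichlorobenzyl gives a 1.7-fold lower number from compound 3 to compound 4 (0.23 log units; within the scatter) in this assay, and this step agrees with the one seen earlier on the other core: the same change on two cores in this assay, a 2.3-fold lower number (0.36 log units; beyond the scatter) from compound 1 to compound 2 and a 1.7-fold lower number (0.23 log units; within the scatter) from compound 3 to compound 4, 1.3-fold (0.13 log units) apart, within the scatter of two such steps. Chloro in place of methyl, read on the compounds that carry the 2,4-dichlorobenzyl group, gives a 2.5-fold higher number from compound 2 to compound 4 (0.40 log units; beyond the scatter), and it also agrees with its earlier counterpart: the same change on two cores in this assay, a 1.9-fold higher number (0.28 log units; within the scatter) from compound 1 to compound 3 and a 2.5-fold higher number (0.40 log units; beyond the scatter) from compound 2 to compound 4, 1.3-fold (0.13 log units) apart, within the scatter of two such steps. So in this small set, each change behaves alike on the two cores, with no sign that its size depends on the other change, but this rests on only four compounds, one step of each pair lies within the scatter, and nothing here shows that either change would carry over to a different core or explains why the numbers move.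

From the compounds shown here alone, it remains open whether another group in the place taken by the second chloro group, such as fluoro, methoxy, an amine or a carboxylic acid, would shift the number further. Also open, going by these compounds, is how these steps would look with a longer chain in place of the benzyl link, or with a group other than methyl or chloro on the core.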